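One Added Methyl on Compound 2

A few compounds are considered here, and "the series" means these few. Any claim that something is new, unique, unknown or untested is made for them only; others in the source may bear on it.

Of the compounds shown here, two have been measured in a functional assay on XF498 cells (Homo sapiens) for cytotoxicity; on this read-out higher numbers stand for weaker inhibition and lower numbers for stronger inhibition. There, compound 1 (`Cc1ccc(-c2cc3ccccc3c(O)n2)cc1`) gives 7080 nM, while compound 2 (`Cc1ccc2c(O)nc(-c3ccccc3)cc2c1`) gives 760 nM. Compound 2 thus holds the lower of the two numbers, and the gap between them lies beyond the usual scatter. Compound 3 (`Cc1ccc2c(O)nc(-c3ccccc3C)cc2c1`) differs from compound 2 in one place: methyl in place of hydrogen on an aromatic carbon, with methyl in place of hydrogen on an aromatic carbon, ortho to a large group. Going by the values given here, no measured pair shows what such a change does in this assay, so any expectation here is loose. A modest rise in the number is expected, one that may stay within the scatter. The estimated change is a 1.7-fold higher number from compound 2 to compound 3 (0.23 log units; within the scatter). For compound 3 the expected value is 1300 nM, with an estimated range from 300 nM to 6000 nM.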

Compound 3, half-maximal inhibitory concentration: 1990 nM
The estimate for compound 3 lay 1.5-fold (0.18 log units) below the measured number; low and high end bracket the measured number.
By their numbers in this assay, from the lowest: compound 2; then compound 3; then compound 1.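

Going by these compounds alone, the step in this assay is the first reading of this position: methyl in place of hydrogen on an aromatic carbon, ortho to a large group, brings a 2.6-fold higher number from compound 2 to compound 3 (0.42 log units; beyond the scatter) and so moves the number towards weaker inhibition. The position therefore responds to the addition of a single carbon, and the change cannot be passed over as neutral on this read-out. Nothing available accounts for why the number moves in this direction.

On these data alone, whether an ethyl group, a methoxy group or a chlorine atom on this same carbon would raise the number further, leave it unchanged or lower it remains open. Within the data shown here, with only this one step, it is also open whether a methyl group on another carbon of this ring would behave the same way.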